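The compounds below may be only part of what the source reports. "The series", "measured", "known", "first", "only" and "open" are said of these compounds alone.

Compound 2 `COc1c(OCCCCN2CCN(C)CC2)cc(O)c2c(=O)cc(-c3ccc([N+](=O)[O-])cc3)oc12` is one of two compounds examined in a functional assay on MCF7 cells (Homo sapiens) for cytotoxicity, read by MTT assay, with a stated time of 72 h (on this read-out lower numbers stand for stronger inhibition and higher numbers for weaker inhibition), and in that assay compound 2 gives 4090 nM. For the measured compounds named here, this is the higher of the two numbers, and its only neighbour is compound 1 `COc1c(OCCCCN2CCN(C)CC2)cc(O)c2c(=O)cc(-c3ccc(C)cc3)oc12`, which in this assay gives 4020 nM; the step of a 1.0-fold higher number from compound 1 to compound 2 (0.01 log units; within the scatter) lies within the scatter. Compound 3 `COc1c(OCCCCN2CCN(C)CC2)cc(O)c2c(=O)cc(-c3ccc(F)cc3Br)oc12` has not yet been measured. Its structure differs from that of compound 2 by 2-bromo-4-fluorophenyl in place of 4-nitrophenyl on an aromatic carbon. Going by the values given here, the one measured step, a 1.0-fold higher number from compound 1 to compound 2 (0.01 log units; within the scatter), bears only loosely on this change, since it concerns a single exchange on the same ring, and it was small. On this evidence no step beyond the scatter is expected in this assay, in either direction. Compound 3 is therefore expected to give about 4000 nM, within a range from 1500 nM to 11000 nM, which means an expected step of a 1.0-fold lower number from compound 2 to compound 3 (0.01 log units; within the scatter).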

Compound 3, half-maximal inhibitory concentration: 3090 nM
Compound 3: middle estimate off by 1.3-fold (0.11 log units), on the high side; the measured number falls inside the stated range.
By their numbers in this assay, from the lowest: compounds 3, 1 and 2 (each within the scatter of the next).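

In this assay, 2-bromo-4-fluorophenyl in place of 4-nitrophenyl on the aromatic carbon next to the ring oxygen gives a 1.3-fold lower number from compound 2 to compound 3 (0.12 log units; within the scatter), and the same group in place of 4-methylphenyl gives a 1.3-fold lower number from compound 1 to compound 3 (0.11 log units; within the scatter). For the compounds shown here, the earlier pair showed only one single group exchanged for another on this aryl ring, whereas compound 3 shows that a ring carrying both bromine and fluorine also stays within the scatter of compound 1 and compound 2, so all three aryl groups read alike at this position. No measurement at hand bears on this result.

On these data alone, it remains open whether an amine, a carboxylic acid or a hydroxyl group on this aryl ring would produce a step beyond the scatter. The shared core also leaves open what a longer chain in the side chain would do.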